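The source may hold more compounds than are shown below. What is called first, only, known or untested is meant among the compounds shown, and "the series" means these compounds.

Two compounds share one core and differ only in the aromatic ring attached to a carbon of that core. Compound 1 `Cc1nn(-c2nc(-c3ccc(Cl)c(Cl)c3)c(SC(C)C)s2)c(C(=O)O)c1-c1cncnc1` carries a pyrimidin-5-yl group there, and in a functional assay on BJAB cells (Homo sapiens) for antiproliferative activity, with a stated time of 4 days (on this read-out higher numbers stand for an effect only at larger amounts of compound and lower numbers for an effect already at smaller amounts), compound 1 gives 22000 nM. Compound 2 `COc1cncc(-c2c(C)nn(-c3nc(-c4ccc(Cl)c(Cl)c4)c(SC(C)C)s3)c2C(=O)O)c1` carries a 5-methoxypyridin-3-yl group in that place, and in this assay compound 2 gives 21000 nM. The step of a 1.0-fold lower number from compound 1 to compound 2 (0.02 log units; within the scatter) is within the scatter, so these two values cannot be told apart. Compound 2 thus stands alongside compound 1 on the numbers shown; the gap between them is within the scatter, and neither can be called the more potent.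

Compound 3 `Cc1cc(Cl)cc(-c2c(C)nn(-c3nc(-c4ccc(Cl)c(Cl)c4)c(SC(C)C)s3)c2C(=O)O)c1` keeps the same core and makes the change (3-chloro-5-methylphenyl in place of 5-methoxypyridin-3-yl on an aromatic carbon). Among the measured compounds shown here, the only measured step, a 1.0-fold lower number from compound 1 to compound 2 (0.02 log units; within the scatter), exchanged one six-membered ring for another at this position and left the number within the scatter. For the measured compounds named here, that step bears on the new change only loosely: the ring that enters carries no ring nitrogen, and no measured compound shows how such a ring behaves here. The expectation is therefore a step of a 1.2-fold lower number from compound 2 to compound 3 (0.07 log units; within the scatter) of no clear direction, with a wide range. Compound 3 is estimated at 18000 nM, between 5000 nM and 60000 nM.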

Compound 3, half-maximal effective concentration: 663 nM
Beside the measured number, compound 3's estimate is 27-fold (1.43 log units) above it; measured number outside the range, below it.
By their numbers in this assay, from the lowest: compound 3; then compounds 2 and 1 (each within the scatter of the next).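

This position is far from indifferent to the ring it carries: in this assay both a 32-fold lower number from compound 2 to compound 3 (1.50 log units; beyond the scatter) and a 33-fold lower number from compound 1 to compound 3 (1.52 log units; beyond the scatter) come with 3-chloro-5-methylphenyl as the entering group. The earlier exchange of pyrimidin-5-yl for 5-methoxypyridin-3-yl showed no measurable difference, so that flat result held only for those two rings and does not extend to every six-membered aromatic ring placed here. Nothing available explains the large drop in the number, and the data give no measured property of either group that could account for it.

This single change replaces a ring containing nitrogen with a ring of carbon only, removes the methoxy group and adds both a chlorine and a methyl, so the compounds shown cannot say which of these differences matters. A plain phenyl ring, or a phenyl ring carrying only the chlorine or only the methyl, would help separate these contributions, while an amine or a longer chain on the ring would test how much more this position can accept.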